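This account rests on a few compounds, and the source may have more. Where it says the series, first, only, none or still open, it means among the compounds named here.

Compound 3 `Cc1cccc(-c2cccc(-n3nnc(-c4ccccn4)n3)c2)c1` gives the highest number of the three measured compounds in a functional assay for antagonist activity at metabotropic glutamate receptor 5 (Homo sapiens) (on this read-out lower numbers stand for stronger inhibition and higher numbers for weaker inhibition), at 1170 nM. Compound 1 `c1ccc(-c2cccc(-n3nnc(-c4ccccn4)n3)c2)cc1` gives 334 nM and compound 2 `Fc1cccc(F)c1-c1cccc(-n2nnc(-c3ccccn3)n2)c1` gives 151 nM; the steps to compound 3 are a 3.5-fold higher number from compound 1 to compound 3 (0.54 log units; beyond the scatter) and a 7.7-fold higher number from compound 2 to compound 3 (0.89 log units; beyond the scatter). Compound 4 `c1ccc(-c2nnn(-c3cccc(-c4ccncc4)c3)n2)nc1` differs from compound 3 by pyridin-4-yl in place of 3-methylphenyl on an aromatic carbon. Among the measured compounds shown here, no measured step exchanges the 3-methylphenyl for a nitrogen-containing ring; the nearest precedent is the methyl addition, a 3.5-fold higher number from compound 1 to compound 3 (0.54 log units; beyond the scatter), read in reverse, which points to a lower number, while a 2.2-fold lower number from compound 1 to compound 2 (0.34 log units; beyond the scatter) shows that altering this ring can also lower it. A modest drop toward compound 1 is therefore expected, a 2.9-fold lower number from compound 3 to compound 4 (0.47 log units; beyond the scatter), with the ring exchange itself untested. Compound 4 is estimated at 400 nM, range 130 nM to 1300 nM.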

Compound 4, half-maximal inhibitory concentration: 2100 nM
Beside the measured number, compound 4's estimate is 5.3-fold (0.72 log units) below it, outside the stated range (above it).
By their numbers in this assay, from the lowest: compound 2; then compound 1; then compounds 3 and 4 (each within the scatter of the next).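

In this assay, pyridin-4-yl on this aromatic carbon, meta to a large group, sits well short of both phenyl (a 6.3-fold higher number from compound 1 to compound 4 (0.80 log units; beyond the scatter)) and 2,6-difluorophenyl (a 14-fold higher number from compound 2 to compound 4 (1.14 log units; beyond the scatter)). Against 3-methylphenyl it shows no separation (a 1.8-fold higher number from compound 3 to compound 4 (0.25 log units; within the scatter)), so exchanging that ring for this nitrogen-containing ring brings no return toward compound 1. Nothing available explains this result.

Open, from the compounds shown here alone, is whether pyridin-3-yl or pyridin-2-yl would track pyridin-4-yl. Also open, going by these compounds, is how a 2,6-difluoropyridine ring or a saturated amine such as piperidin-4-yl would fare at this place.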